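The source may report more compounds than this note shows. Statements on the series, on what has been measured and on what is new or still open speak of the compounds shown alone.

Of the compounds shown here, two have been measured. Compound 1 is `Cc1cc2ncn(-c3ccc4c(N)nc(N)nc4c3)c2cc1C` and compound 2 is `Cc1cc2nc(-c3cccs3)n(-c3ccc4c(N)nc(N)nc4c3)c2cc1C`. In an assay on isolated protein for inhibition of Dihydrofolate reductase (Homo sapiens), read by spectrophotometry, using NADPH, with a stated time of 10 min (a lower number here means a stronger inhibitor, a higher number a weaker inhibitor), compound 1 gives 1610 nM, and compound 2 gives 1030 nM. Compound 2 stands at the lower end of the two numbers shown, but its gap to compound 1 is within the scatter, so the two are not told apart. Among the measured compounds shown here, the single measured step, a 1.6-fold lower number from compound 1 to compound 2 (0.19 log units; within the scatter), is the only guide to how a five-membered aromatic ring on this aromatic carbon matters. Compound 3, `Cc1cc2nc(-c3cccn3C)n(-c3ccc4c(N)nc(N)nc4c3)c2cc1C`, follows from compound 2 with 1-methyl-1H-pyrrol-2-yl in place of thiophen-2-yl on an aromatic carbon. For the measured compounds named here, no measured pair exchanges one such ring for another; the nearest evidence is that adding the thiophen-2-yl ring at all moved the number only within the scatter, so a step in this assay of no more than the scatter is expected, in either direction. Compound 3 is therefore expected to give 1100 nM, within a range from 500 nM to 2500 nM. The expected step is a 1.1-fold higher number from compound 2 to compound 3 (0.03 log units; within the scatter).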

Compound 3, inhibition constant: > 5000 nM
Compound 3 was reported as a limit; the forecaster's own chance of this, stated with the estimate: 3%; at least 4.5-fold (0.65 log units) between middle value and limit.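

Compound 3 is reported only as a limit of the assay, not as a number: the limit of > 5000 nM in this assay, at which 1 of the 3 values shown sits. In this assay this position, between two ring nitrogen atoms, proves sensitive to which five-membered aromatic ring it carries: 1-methyl-1H-pyrrol-2-yl in place of thiophen-2-yl gives an at least 4.8-fold higher number from compound 2 to compound 3 (0.68 log units; beyond the scatter). Set against hydrogen on this carbon, the same ring gives an at least 3.1-fold higher number from compound 1 to compound 3 (0.49 log units; beyond the scatter), so a group here can weaken inhibition, which thiophen-2-yl did not show.

The compounds shown do not tell whether the exchange of sulfur for nitrogen or the added methyl carries this step. As far as these compounds go, how the pyrrol-2-yl ring without its methyl, or a group such as an amine or a carboxylic acid, behaves at this position also stays open.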